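The source may hold more compounds than are shown below. What is called first, only, known or untested is meant among the compounds shown, and "the series" means these compounds.

Measured in a functional assay on MCF7 cells (Homo sapiens) for antiproliferative activity, read by MTT assay, with a stated time of 48 h; on this read-out higher numbers stand for weaker inhibition and lower numbers for stronger inhibition:

- compound 1 `CC(=O)N1N=C(c2ccc3ccccc3c2)OC1c1ccc(Br)cc1`: 5.07 ug/mL
- compound 2 `CC(=O)N1N=C(c2ccc3ccccc3c2)OC1c1ccc(Cl)cc1`: 2.63 ug/mL
- compound 3 `CC(=O)N1N=C(c2ccc3ccccc3c2)OC1c1ccccc1F`: 3.44 ug/mL

Compound 2, at 2.63 ug/mL, cannot be separated from the other two compounds, since its steps to both stay within the scatter. The next structure, compound 4 `CC(=O)N1N=C(c2ccc3ccccc3c2)OC1c1ccc([N+](=O)[O-])cc1`, has nitro in place of chloro on an aromatic carbon, para to a large group, taking 4-chlorophenyl to 4-nitrophenyl (nitro in place of chloro on an aromatic carbon).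

The closest evidence is a 1.9-fold lower number from compound 1 to compound 2 (0.29 log units; within the scatter), where chloro replaces bromo. The changes of aryl group give a 1.5-fold lower number from compound 1 to compound 3 (0.17 log units; within the scatter) and a 1.3-fold higher number from compound 2 to compound 3 (0.12 log units; within the scatter). All three steps are small, but none involves nitro, so they offer only a loose guide to this change. In this assay, no step beyond the scatter is therefore expected, and no direction is favoured. The estimated step is a 1.1-fold higher number from compound 2 to compound 4 (0.06 log units; within the scatter). For compound 4, the expected value is 3 ug/mL, with an estimated range of 1.2 ug/mL to 7.5 ug/mL.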

Compound 4, half-maximal inhibitory concentration: 7.59 ug/mL
Compound 4: the middle estimate sits 2.5-fold (0.40 log units) below what was measured, and the stated range ends below it.
By their numbers in this assay, from the lowest: compounds 2, 3, 1 and 4 (each within the scatter of the next, the first and the last beyond it).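

In this assay, within the data shown here, nitro on this aromatic carbon, para to a large group, gives the first change to reach beyond the scatter, though only modestly, against both the chloro compound (a 2.9-fold higher number from compound 2 to compound 4 (0.46 log units; beyond the scatter)) and the 2-fluorophenyl compound (a 2.2-fold higher number from compound 3 to compound 4 (0.34 log units; beyond the scatter)). The bromo compound stays inseparable from the nitro compound (a 1.5-fold higher number from compound 1 to compound 4 (0.18 log units; within the scatter)), so this place can separate compounds, but compound 1 and compound 4 cannot be told apart, and only compound 2 and compound 3 stand clearly apart from compound 4. No accompanying measurement bears on why the numbers fall this way.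

On these data alone, it remains open whether an amine, a carboxylic acid or a methoxy group at this same place would stay with the chloro compound or with the nitro compound. The compounds shown also leave open whether the step from chloro to nitro would hold on another core.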